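Chalcone analogues: methoxy pattern on the carbonyl-side ring

A few compounds are considered here, and "the series" means these few. Any claim that something is new, unique, unknown or untested is made for them only; others in the source may bear on it.

Compound 1 `O=C(/C=C/c1cn(-c2ccccc2)nc1-c1ccsc1)c1ccccc1` was tested in a functional assay on MCF7 cells (Homo sapiens) for inhibition, read by sulforhodamine B assay, with a stated time of 72 h (a higher number here means a weaker inhibitor, a lower number a stronger inhibitor), where compound 1 gives 1900 nM. Its companion compound 2 `COc1cc(OC)c(C(=O)/C=C/c2cn(-c3ccccc3)nc2-c2ccsc2)c(OC)c1` gives 2700 nM in this assay; the two numbers lie within the usual scatter of each other, so neither stands apart. Compound 3 `COc1ccc(OC)c(C(=O)/C=C/c2cn(-c3ccccc3)nc2-c2ccsc2)c1` carries the change (2,5-dimethoxyphenyl in place of phenyl on a carbonyl carbon). With compound 2 giving a value so close to that of compound 1, a step from compound 1 to compound 3 is expected to be none beyond the scatter, as a 1.2-fold higher number from compound 1 to compound 3 (0.06 log units; within the scatter). Compound 3 is therefore expected to give about 2200 nM in this assay, with a range from 900 nM to 5500 nM.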

Compound 3, half-maximal inhibitory concentration: 400 nM
For compound 3 the middle estimate is 5.5-fold (0.74 log units) above the measured one; measured number outside the range, below it.
By their numbers in this assay, from the lowest: compound 3; then compounds 1 and 2 (each within the scatter of the next).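

In this assay the 2,5-dimethoxyphenyl group on a carbonyl carbon gives a 4.8-fold lower number from compound 1 to compound 3 (0.68 log units; beyond the scatter) and so shows that this position does respond to a change of ring, which the close values of compound 1 and compound 2 had not revealed. Adding methoxy groups here thus has no uniform outcome: compound 2 stays within the scatter of compound 1, while compound 3 does not. Nothing available explains this difference. As far as these compounds go, it remains open whether one methoxy group would suffice, and whether ethoxy or an amine could replace the methoxy groups of compound 3 without losing the lower number.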